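Swapping a halogen-bearing benzyl group in a triazolopyrimidine series

The source may hold more compounds than are shown below. What is called first, only, known or untested is meant among the compounds shown, and "the series" means these compounds.

Of the compounds shown here, three sharing one core have been measured in a functional assay on MCF7 cells (Homo sapiens) for antiproliferative activity, read by MTT assay, with a stated time of 72 h; on this read-out lower numbers stand for stronger inhibition and higher numbers for weaker inhibition. Compound 1 `CCCSc1nc(N/N=C/c2ccccc2Cl)c2nnn(Cc3ccccc3)c2n1` gives 13800 nM in this assay. Compound 2 `CCCSc1nc(N/N=C(\C)c2ccc(OC)cc2)c2nnn(Cc3ccccc3)c2n1` reaches only the limit of this assay, > 64000 nM. On these data alone, compound 3 `CCCSc1nc(N/N=C(\C)c2ccccc2O)c2nnn(Cc3ccccc3Cl)c2n1` likewise stops at the limit of this assay, > 64000 nM, so its exact position is unknown; it stands at the limit of > 64000 nM in this assay, at which 2 of the 3 values shown sit, together with compound 2, while compound 1 alone returns a number. Compound 4 `CCCSc1nc(N/N=C(\C)c2ccccc2O)c2nnn(Cc3ccc(Br)cc3)c2n1` differs from compound 3 in one place: 4-bromophenyl in place of 2-chlorophenyl on a saturated chain carbon bound to an aromatic nitrogen. Going by the values given here, no measured pair in this set differs by that change alone, so no directly comparable step exists. Because compound 3 sits at the limit > 64000 nM and keeps the same hydrazone part in compound 4, compound 4 is expected to remain weak, with the step from compound 3 to compound 4 estimated as a step that the limit leaves unreadable from compound 3 to compound 4, within the usual scatter. The estimated value for compound 4 in this assay is 70000 nM, in the range 20000 nM to 250000 nM, and it may well register only as a limit again.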

Compound 4, half-maximal inhibitory concentration: 15600 nM
For compound 4 the middle estimate is 4.5-fold (0.65 log units) above the measured one; measured number below the stated range.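

Changing only 2-chlorobenzyl to 4-bromobenzyl, with the rest of the molecule held fixed, gives in this assay an at least 4.1-fold lower number from compound 3 to compound 4 (0.61 log units; beyond the scatter), so this position alone can bring a compound in this series off the limit of the assay. Going by these compounds alone, none of the earlier compounds formed a pair differing in one place, so this is the first single change that can be read here. The printed size is only a lower bound, as compound 3 gives a limit rather than a number, and it shares that limit with compound 2: the limit of > 64000 nM in this assay, at which 2 of the 4 values shown sit.

The swap changes both the halogen and its place on the ring, so 4-chlorobenzyl or 2-bromobenzyl would be needed to separate the two. On these data alone, it also remains open whether an unsubstituted benzyl or 4-methoxybenzyl group at this position would retain the activity of compound 4.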